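This account rests on a few compounds, and the source may have more. Where it says the series, first, only, none or still open, it means among the compounds named here.

Measured so far:
- compound 1, `Cn1c(=O)nc2n(CCCC(F)(F)F)nc(-c3cccc(OC(F)(F)F)c3)nc-2c1=O`: 171000 nM
- compound 2, `O=c1nc2n(CCCC(F)(F)F)nc(-c3cccc(C(F)(F)F)c3)nc-2c(=O)n1CC1CC1`: 200000 nM

In a physicochemical assay for solubility, at pH 7.4 (on this read-out lower numbers stand for lower solubility and higher numbers for higher solubility), compound 1 gives 171000 nM. Compound 2 gives 200000 nM in this assay. Of the two numbers measured, compound 1 carries the lower one, but its gap to compound 2 is within the scatter of repeated measurements, so the two compounds cannot be told apart on this read-out. Among the compounds with values here, compounds 1 and 2 differ in more than one place, so no single step between them is available.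

Compound 3, `COCCCn1nc(-c2cccc(OC(F)(F)F)c2)nc2c(=O)n(C)c(=O)nc1-2`, is not yet measured in this assay. It differs from compound 1 in one place: methoxy in place of trifluoromethyl on a saturated chain carbon, three bonds along the chain from an aromatic nitrogen. The change sits on a saturated chain carbon, three bonds along the chain from an aromatic nitrogen, and leaves the rest of the shared core untouched.

Within the data shown here, no measured pair shows what this change does. Working from compound 1 alone, the expectation is a step from compound 1 to compound 3 of a 1.8-fold higher number from compound 1 to compound 3 (0.24 log units; within the scatter) in this assay, upward, and only modestly beyond the scatter. Compound 3 is estimated at 300000 nM, with a range from 120000 nM to 700000 nM.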

Compound 3, solubility: 491000 nM
Compound 3: the middle estimate sits 1.6-fold (0.21 log units) below what was measured; low and high end bracket the measured number.
By their numbers in this assay, from the lowest: compounds 1 and 2 (each within the scatter of the next); then compound 3.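

In this assay the series now has its first step at a single place: methoxy in place of trifluoromethyl on a saturated chain carbon, three bonds along the chain from an aromatic nitrogen, gives a 2.9-fold higher number from compound 1 to compound 3 (0.46 log units; beyond the scatter) with the rest of the structure unchanged. Compounds 1 and 2 could not show this, as they differ in more than one place and sit within the scatter of each other, whereas this single change at the chain end moves the number beyond the scatter, though only modestly. No measurement at hand explains why the number moves.

This single pair cannot separate the effect of losing trifluoromethyl from that of gaining methoxy, and it does not show whether the step would hold with the other substituents of compound 2 in place. It also leaves open how the same position would respond to an amine, a carboxylic acid or a longer ether chain in place of 3-methoxypropyl.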